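The compounds below may be only part of what the source reports. "The series", "measured", "known", "first", "only" and "open" are said of these compounds alone.

In a functional assay on RXF 393 cells (Homo sapiens) for cytotoxicity, read by sulforhodamine B assay, with a stated time of 48 h, tested at 10 uM (on this read-out lower numbers stand for a stronger effect and higher numbers for a weaker effect at the one concentration tested), compound 2 `COc1cc(C)cc(-c2nn(CC#N)cc2-c2ccnc(-c3ccc(N(C)C)cc3)c2)c1` gives -24%, the highest of the two numbers recorded; compound 1 `Cc1cc(O)cc(-c2nn(CC#N)cc2-c2ccnc(-c3ccc(Oc4ccccc4)cc3)c2)c1` gives -87% in this assay, a gap beyond the usual scatter. Compound 3 `Cc1cc(O)cc(-c2nn(CC#N)cc2-c2ccnc(-c3ccc(N(C)C)cc3)c2)c1` differs from compound 2 by hydrogen in place of methyl on an oxygen on an aromatic ring. Going by the values given here, no pair of measured compounds isolates this change: compound 1 also carries the hydroxy, but differs from compound 2 elsewhere as well, so its value cannot be assigned to the hydroxy alone. A modest move toward a stronger effect is expected, a number 21 percentage points lower from compound 2 to compound 3 (beyond the scatter), possibly not beyond the scatter. Compound 3 is estimated at -45%, within -85% to -10%.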

Compound 3, a percentage reported as activity, at one concentration (the size of the read-out at that concentration, not a potency): -46%
Estimate against measurement, compound 3: 1 percentage points above; the measured number falls inside the stated range.
By their numbers in this assay, from the lowest: compound 1; then compound 3; then compound 2.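

In this assay the change from methoxy to hydroxy can now be read on its own, with dimethylamino held fixed: there is a number 22 percentage points lower from compound 2 to compound 3 (beyond the scatter) at this oxygen on the aromatic ring. Compound 3 also opens the other site, with dimethylamino in place of phenoxy giving a number 41 percentage points higher from compound 1 to compound 3 (beyond the scatter) and so a large step. Nothing measured here explains either step. On these data alone, whether an ethoxy or an amine at that place would match the hydroxy stays open, as does whether the phenoxy step holds with methoxy in place of hydroxy.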